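The source may hold more compounds than are shown below. What is called first, only, known or untested is meant among the compounds shown, and "the series" means these compounds.

Measured so far:
- compound 1, `COc1cc(/C=C/C(=O)c2sc(Nc3ccc(Cl)c(Cl)c3)nc2C)cc(OC)c1OC` — > 25000 nM
- compound 2, `Cc1ccccc1Nc1nc(C)c(C(=O)/C=C/c2ccccc2)s1` — > 25000 nM
- compound 3, `Cc1cccc(Nc2nc(C)c(C(=O)/C=C/c3ccccc3)s2)c1` — > 25000 nM

In a functional assay on Bel-7402 cells (Homo sapiens) for cytotoxicity, read by MTT assay (a higher number here means a weaker inhibitor, a lower number a stronger inhibitor), compound 1 gives > 25000 nM, which is a limit of the assay rather than a number. Compound 2 likewise gives only a limit, > 25000 nM. Compound 3 also gives only a limit, > 25000 nM. Going by the values given here, because of the limit of > 25000 nM in this assay, at which 3 of the 3 values shown sit, no step between these compounds can be read: the change a step that the two limits leave unreadable from compound 2 to compound 3 has no readable size. Compound 1 therefore stands at the limit, alongside the other two, with no value that would rank them.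

The unmeasured compound 4, `COc1cc(/C=C/C(=O)c2sc(Nc3ccc(Cl)cc3)nc2C)cc(OC)c1OC`, differs from compound 1 as follows: hydrogen in place of chloro on an aromatic carbon. No measured step involves a chloro group, so none bears on this change, and the data give no reason to expect compound 4 to move away from where compound 1 sits. The step that the limit leaves unreadable from compound 1 to compound 4 is the expected outcome, no more than the scatter. Compound 4 is thus estimated at 30000 nM in this assay, with a range from 10000 nM to 100000 nM.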

Compound 4, half-maximal inhibitory concentration: > 25000 nM
Compound 4: a limit, no number; the forecaster's own chance of this, stated with the estimate: 80%; the middle value does not contradict the limit.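

Compound 1 and compound 4 each give only a limit of the assay and not a number, so no step between them can be read: the limit of > 25000 nM in this assay, at which 4 of the 4 values shown sit.

The compounds shown leave open whether any change to this series can bring a readable value in this assay.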